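This account rests on a few compounds, and the source may have more. Where it says the series, first, only, none or still open, it means among the compounds named here.

Working notes on the carbamate variations of the shared core. In a functional assay on CHO-K1 cells for agonist activity at Glucose-dependent insulinotropic receptor (Homo sapiens), read by a luciferase reporter, with a stated time of 5 h (on this read-out lower numbers stand for an effect already at smaller amounts and higher numbers for an effect only at larger amounts of compound), compound 2 `CC(C)(C)OC(=O)N1CCC(Oc2ncnc3c2CCN3c2ccc(S(C)(=O)=O)cc2F)CC1` gives 20 nM. Compound 3 `COC(=O)N1CCC(Oc2ncnc3c2CCN3c2ccc(S(C)(=O)=O)cc2F)CC1`, which carries methyl in place of tert-butyl on the oxygen next to the carbonyl group, gives 316 nM in this assay; the step is a 16-fold higher number from compound 2 to compound 3 (1.20 log units; beyond the scatter). Compound 1 `CC(C)OC(=O)N1CCC(Oc2ncnc3c2CCN3c2ccc(C#N)cc2F)CC1` carries isopropyl on that oxygen and a nitrile where compound 2 and compound 3 carry a methylsulfonyl group; in this assay compound 1 gives 63.1 nM. Compound 3 thus stands highest of the three numbers, beyond the scatter from both compound 1 and compound 2.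

Compound 4 `CCCOC(=O)N1CCC(Oc2ncnc3c2CCN3c2ccc(S(C)(=O)=O)cc2F)CC1` differs from compound 3 by ethyl in place of hydrogen on a saturated chain carbon bound to an oxygen next to a carbonyl group. For the measured compounds named here, the only single-point step that bears on this is the one from compound 2 to compound 3, in which shortening tert-butyl to methyl raised the number by a large amount; propyl lies between those two in chain length, so a partial return toward the lower numbers is expected. Going by the values given here, compound 1, with its isopropyl, sits at a lower number than compound 3, but its other substituent differs, so no step is drawn from it. The step of a 4.0-fold lower number from compound 3 to compound 4 (0.60 log units; beyond the scatter) is expected to fall clearly below the scatter toward lower numbers. Compound 4 is therefore estimated at 80 nM, in a range from 30 nM to 200 nM.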

Compound 4, half-maximal effective concentration: 79.4 nM
The estimate for compound 4 lay 1.0-fold (0.00 log units) above the measured number; the measured number falls inside the stated range.
By their numbers in this assay, from the lowest: compound 2; then compounds 1 and 4 (each within the scatter of the next); then compound 3.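

In this assay, propyl in place of methyl on the oxygen next to a carbonyl group gives a 4.0-fold lower number from compound 3 to compound 4 (0.60 log units; beyond the scatter), so a low number at this position does not require tert-butyl: an unbranched chain already lowers it beyond the scatter. Propyl does not match tert-butyl, however, as a 4.0-fold higher number from compound 2 to compound 4 (0.60 log units; beyond the scatter) also lies beyond the scatter, and this position therefore separates all three groups, with methyl highest and tert-butyl lowest among compound 2, compound 3 and compound 4. Nothing at hand accounts for this order.

As far as these compounds go, whether the remaining gap to compound 2 follows chain length or branching stays open, since propyl and tert-butyl differ in both. From the compounds shown here alone, how a longer chain such as butyl, or a ring such as cyclobutyl, would read on this oxygen with the methylsulfonyl group in place also stays open.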